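This account rests on a few compounds, and the source may have more. Where it says the series, first, only, none or still open, it means among the compounds named here.

Measured compounds: compound 1 `C#CCCCOc1ccc2cc(NC(C)=O)c(=O)oc2c1`, 43.6 nM; compound 2 `C#CCCCCOc1ccc2cc(NC(C)=O)c(=O)oc2c1`, 41.7 nM; compound 3 `C#CCCCCOc1ccc2ccc(=O)oc2c1`, 2.62 nM; all in an assay on cells for inhibition of Amine oxidase [flavin-containing] B (Homo sapiens), read by Amplex Red, with stated times of 30 min and 45 min; on this read-out higher numbers stand for weaker inhibition and lower numbers for stronger inhibition.

Compound 2 sits alongside compound 1, a 1.0-fold lower number from compound 1 to compound 2 (0.02 log units; within the scatter), and well away from compound 3, a 16-fold lower number from compound 2 to compound 3 (1.20 log units; beyond the scatter). Compound 4 `CC(=O)Nc1cc2ccc(OCc3cccc(Cl)c3)cc2oc1=O` keeps the acetamido of compound 2 and differs only in the ether chain: 3-chlorophenyl in place of pent-4-yn-1-yl on a saturated chain carbon bound to an oxygen on an aromatic ring. For the measured compounds named here, no measured step exchanges a chain for an aromatic ring. Going by the values given here, the one step at that site, a 1.0-fold lower number from compound 1 to compound 2 (0.02 log units; within the scatter), shows chain length alone is immaterial here, and a 16-fold lower number from compound 2 to compound 3 (1.20 log units; beyond the scatter) concerns the acetamido, which compound 4 retains. The expected step in this assay is therefore uncertain and is set as a modest move toward lower numbers, a 2.1-fold lower number from compound 2 to compound 4 (0.32 log units; beyond the scatter). Compound 4 is estimated at 20 nM, range 5 nM to 80 nM.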

Compound 4, half-maximal inhibitory concentration: 13.5 nM
Compound 4: middle estimate off by 1.5-fold (0.17 log units), on the high side; the measured number falls inside the stated range.
By their numbers in this assay, from the lowest: compound 3; then compound 4; then compounds 2 and 1 (each within the scatter of the next).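

In this assay, 3-chlorophenyl in place of pent-4-yn-1-yl (a 3.1-fold lower number from compound 2 to compound 4 (0.49 log units; beyond the scatter)) and in place of but-3-yn-1-yl (a 3.2-fold lower number from compound 1 to compound 4 (0.51 log units; beyond the scatter)) moves the number beyond the scatter. This site therefore responds to an aromatic ring, although the two alkyne chains gave no separation, and it does so with the acetamido retained. Nothing measured here gives a reason for this shift.

The compounds shown leave open whether the chlorine or the ring accounts for the step, which a plain benzyl ether would test. Also open, as far as these compounds go, is whether 3-chlorobenzyl would give a similar step on the core of compound 3, which lacks the acetamido.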